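Alkyne-linked ring variation on a shared core

The source may hold more compounds than are shown below. What is called first, only, known or untested is meant among the compounds shown, and "the series" means these compounds.

Three compounds share one core and differ only in the ring attached to the triple-bonded carbon. Compound 1 `CNC(=O)[C@@]12C[C@@H]1[C@@H](n1cnc3c(NC)nc(C#Cc4ccc(Cl)cc4)nc31)[C@H](O)[C@@H]2O` gives 13% in an assay on CHO cells for displacement of a labelled ligand from adenosine receptor A1 (Homo sapiens), read by scintillation counting, with a stated time of 60 min, tested at 10 uM; on this read-out higher numbers stand for more inhibition at the one concentration tested (going by the name of the read-out) and lower numbers for less inhibition. Compound 2 `CNC(=O)[C@@]12C[C@@H]1[C@@H](n1cnc3c(NC)nc(C#Cc4cccnc4)nc31)[C@H](O)[C@@H]2O` gives 16% in this assay, and compound 3 `CNC(=O)[C@@]12C[C@@H]1[C@@H](n1cnc3c(NC)nc(C#Cc4cccnn4)nc31)[C@H](O)[C@@H]2O` gives 11% in this assay. The steps among them are all small: a number 3 percentage points higher from compound 1 to compound 2 (within the scatter), a number 2 percentage points lower from compound 1 to compound 3 (within the scatter) and a number 5 percentage points lower from compound 2 to compound 3 (within the scatter). Compound 3 therefore stands together with compound 1 and compound 2, none of the three separated from another beyond the scatter.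

Compound 4 `CNC(=O)[C@@]12C[C@@H]1[C@@H](n1cnc3c(NC)nc(C#Cc4nccs4)nc31)[C@H](O)[C@@H]2O` has not yet been measured. Its change from compound 3 is 1,3-thiazol-2-yl in place of pyridazin-3-yl on a triple-bonded carbon. The measured steps that bear on it are those in which the ring on the triple-bonded carbon was exchanged: from compound 1 to compound 2, from compound 1 to compound 3 and from compound 2 to compound 3, each within the scatter. Three such ring swaps, covering a chlorinated phenyl and two six-membered nitrogen rings, moved this assay by no more than the scatter. A five-membered ring is a new element here, so a step no larger than the scatter is expected, with no direction preferred: the expected step is a number 2 percentage points higher from compound 3 to compound 4 (within the scatter). Compound 4 is estimated at 13%, with a range from 4% to 24%.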

Compound 4, a percentage reported as inhibition, at one concentration (the size of the read-out at that concentration, not a potency): 31%
Estimate against measurement, compound 4: 18 percentage points below; measured number outside the range, above it.
By their numbers in this assay, from the lowest: compounds 3, 1 and 2 (each within the scatter of the next); then compound 4.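

The ring on the triple-bonded carbon is not silent in this assay: 1,3-thiazol-2-yl gives a number 20 percentage points higher from compound 3 to compound 4 (beyond the scatter), a number 15 percentage points higher from compound 2 to compound 4 (beyond the scatter) and a number 18 percentage points higher from compound 1 to compound 4 (beyond the scatter), whereas the exchanges among 4-chlorophenyl, pyridin-3-yl and pyridazin-3-yl stayed within the scatter. With all three steps beyond the scatter, compound 4 stands apart as the highest of the four, and the change that sets it apart is the only one here that brings in a five-membered aromatic ring and a sulfur atom, though the steps remain modest and this read-out comes from one concentration. No measurement shown here accounts for the rise, so its origin remains unexplained.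

The compounds shown leave open whether the rise goes with the five-membered ring or with the sulfur atom, a question that thiophen-2-yl and 1,3-oxazol-2-yl on the same triple-bonded carbon would help to separate. Also open, going by these compounds, is how substitution on the thiazole itself, such as a methyl group or an aminomethyl group, would change the number in this assay.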